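The compounds below may be only part of what the source reports. "The series", "measured", "known", "first", "only" and "open" are said of these compounds alone.

Measured so far:
compound 1, `Cc1ccc(S(=O)(=O)NCc2ccc(CNC(=O)c3ccc(F)nc3)cc2)cc1`: > 1000 nM
compound 2, `O=C(NCc1ccc(CNS(=O)(=O)c2cccc3ccccc23)cc1)c1ccc(F)cc1`: 1000 nM
compound 3, `Cc1ccc(S(=O)(=O)NCc2ccc(CNC(=O)c3ccc(F)cn3)cc2)cc1`: 1000 nM

In an assay on MDA-MB-231 cells for binding affinity to C-X-C chemokine receptor type 4 (Homo sapiens), read by fluorescence and microscopy, with stated times of 10 min and 30 min (on this read-out higher numbers stand for an effect only at larger amounts of compound and lower numbers for an effect already at smaller amounts), compound 1 gives > 1000 nM, which is a limit of the assay rather than a number. Compound 2 gives 1000 nM in this assay, and compound 3 gives 1000 nM, so compound 2 and compound 3 stand level at the digits shown, within the usual scatter. Going by the values given here, the one step measured between compounds that differ in a single place runs a number no higher from compound 1 to compound 3 (the limit leaves the size open); it concerns the group on the carbonyl carbon, and one of its ends sits at the limit of > 1000 nM in this assay, at which 1 of the 3 values shown sits, so its size stays open.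

Compound 4, `O=C(NCc1ccc(CNS(=O)(=O)c2cccc(C(F)(F)F)c2)cc1)c1ccc(F)cc1`, is not yet measured. It differs from compound 2 at the sulfonyl sulfur: 3-(trifluoromethyl)phenyl in place of naphthalen-1-yl on a sulfonyl sulfur. Among the compounds with values here, no measured step touches this part of the shared core; the only step known lies on the other side of the molecule. There is therefore no measured basis for expecting a step of any particular size or direction, and the expectation for compound 4 rests on compound 2 alone. Compound 4 is thus expected to give about 1000 nM in this assay, within a range from 300 nM to 3000 nM, which means an expected step of no change at the digits printed from compound 2 to compound 4 (within the scatter).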

Compound 4, effective concentration (reported as EC, without a stated level of effect): 100 nM
Estimate against measurement, compound 4: 10-fold (1.00 log units) above; the measured number lies below the stated range.
By their numbers in this assay, from the lowest: compound 4; then compounds 2 and 3 (each within the scatter of the next).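

In this assay, the group on the sulfonyl sulfur turns out to matter: replacing naphthalen-1-yl with 3-(trifluoromethyl)phenyl gives a 10-fold lower number from compound 2 to compound 4 (1.00 log units; beyond the scatter). Going by these compounds alone, this is the first step whose size can be read, as the earlier one, on the carbonyl carbon, ended at a limit of the assay. Both groups count 10 heavy atoms, so the step does not go with a change in that count, although the entering group has one aromatic ring in place of two and brings in fluorine, and nothing measured here gives a reason for the lower number.

Going by these compounds, whether the step follows the trifluoromethyl group or the loss of the second ring stays open, and a plain phenyl or a 3-methylphenyl on the sulfonyl sulfur would help to separate the two. Also open, on these data alone, is whether 3-(trifluoromethyl)phenyl would bring a similar step to compound 3, which carries 5-fluoropyridin-2-yl on the carbonyl carbon, and how an amine or a carboxylic acid on that aromatic ring would read.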